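From 4-Methoxyphenyl to Cyclobutyl on the Shared Core

The source may hold more compounds than are shown below. What is called first, only, known or untested is meant among the compounds shown, and "the series" means these compounds.

In a functional assay on HCT-116 cells (Homo sapiens) for cytotoxicity, read by MTT assay, with a stated time of 72 h (on this read-out higher numbers stand for weaker inhibition and lower numbers for stronger inhibition), compound 1 (`CC(C)(C)c1nc2ccccc2n1C(=O)c1cccc2ccccc12`) reaches only a limit, > 10000 nM. Among the measured compounds shown here, compound 2 (`COc1ccc(-c2nc3ccccc3n2C(=O)c2cccc3ccccc23)cc1`) gives 1700 nM, so far the only actual number in this assay. Compound 3 (`O=C(c1cccc2ccccc12)n1c(C2CCC2)nc2ccccc21`) is still unmeasured and differs from compound 2 on an aromatic carbon, where cyclobutyl takes the place of 4-methoxyphenyl: cyclobutyl in place of 4-methoxyphenyl on an aromatic carbon. For the measured compounds named here, one measured step bears on this change: an at least 5.8-fold lower number from compound 1 to compound 2 (0.76 log units; beyond the scatter). That step put 4-methoxyphenyl in place of tert-butyl, and compound 3 also gives up 4-methoxyphenyl for a group that is not aromatic. But cyclobutyl is not tert-butyl, and a single step is thin support. A higher number, meaning weaker inhibition, is therefore expected. The expected size of the change is a 3.5-fold higher number from compound 2 to compound 3 (0.55 log units; beyond the scatter). For compound 3, the estimated value is 6000 nM, with an expected range of 2000 nM to 15000 nM.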

Compound 3, half-maximal inhibitory concentration: > 10000 nM
Compound 3 was reported as a limit (the forecaster's own chance of this, stated with the estimate: 40%); middle value at least 1.6-fold (0.22 log units) away from the limit.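

Cyclobutyl in place of 4-methoxyphenyl gives an at least 5.8-fold higher number from compound 2 to compound 3 (0.76 log units; beyond the scatter). Among the compounds shown, both groups without an aromatic ring, tert-butyl in compound 1 and cyclobutyl in compound 3, now go with weaker inhibition than the 4-methoxyphenyl of compound 2, so the earlier result no longer rests on tert-butyl alone. The step between compound 1 and compound 3 cannot be read, and the two groups cannot be ordered, because both compounds stop at the same limit: the limit of > 10000 nM in this assay, at which 2 of the 3 values shown sit.

Going by these compounds, it remains open whether the benefit in compound 2 comes from the aromatic ring itself or from its methoxy group, a question that an unsubstituted phenyl at this position would address. On these data alone, how an amine or a longer chain would behave on this aromatic carbon also remains unknown.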